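Replacing the 3-fluoro-2-methylbenzyl group of compound 3

This account rests on a few compounds, and the source may have more. Where it says the series, first, only, none or still open, it means among the compounds named here.

In a toxicity assay on MT2 cells (Homo sapiens) for cytotoxicity (on this read-out lower numbers stand for higher toxicity in this test and higher numbers for lower toxicity in this test), compound 1 (`Cc1nc(C)c([C@H](OC(C)(C)C)C(=O)O)c(N2CCC(C)(C)CC2)c1C1=CCN(CCCc2ccc(F)cc2)CC1`) gives >= 22000 nM as its reading, and this is a limit of the assay, not a number. Compound 2 (`Cc1nc(C)c([C@H](OC(C)(C)C)C(=O)O)c(N2CCC(C)(C)CC2)c1-c1cnn(CCCc2ccc(F)cc2)c1`) gives >= 22000 nM as its reading, again a limit. Compound 3 (`Cc1nc(C)c([C@H](OC(C)(C)C)C(=O)O)c(N2CCC(C)(C)CC2)c1-c1ccc2c(c1)CCN(Cc1cccc(F)c1C)C2`) gives >= 24000 nM as its reading, also a limit. Compound 3 therefore has no exact value, and neither do the other two, so no order among the three can be read from these results.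

Compound 4 (`Cc1nc(C)c([C@H](OC(C)(C)C)C(=O)O)c(N2CCC(C)(C)CC2)c1-c1ccc2c(c1)CCN(c1nc3cnccc3s1)C2`) keeps the shared core and differs from compound 3 in one group, on an amine nitrogen in a ring. The 3-fluoro-2-methylbenzyl group leaves, and a group with no common name enters (a group of 9 heavy atoms (6 carbon, 2 nitrogen, 1 sulfur; one five-membered aromatic ring with 2 hetero atoms, one six-membered aromatic ring with 1 hetero atom) in place of a group of 9 heavy atoms (8 carbon, 1 fluorine; one six-membered aromatic ring of carbon only), on an amine nitrogen in a ring). For the measured compounds named here, no measured pair shows what a change at this place does. The expectation therefore rests on compound 3 at >= 24000 nM as a limit, and on the limits seen across the set (the limit of >= 22000 nM in this assay, at which 2 of the 3 values shown sit, and (the limit of >= 24000 nM in this assay, at which 1 of the 3 values shown sits)). In this assay no shift beyond the usual scatter is expected, and no direction can be favoured. The estimated step (an at least 1.0-fold lower number from compound 3 to compound 4 (0.03 log units; that floor lies within the scatter)) is expected to stay small. For compound 4 the estimate is 22000 nM with an expected span from 9000 nM to 45000 nM as its range.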

Compound 4, half-maximal cytotoxic concentration: >= 17000 nM
Compound 4 gave a limit, no number; the forecaster's own chance of this, stated with the estimate: 65%; the middle value lies beyond the limit too.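

For the compounds shown here, compound 3 and compound 4 each give only a limit, not a number, in this assay, so no step between them can be read. The compounds shown leave open what exact reading any of them would give, and whether changing the group on the amine nitrogen in the ring alters that reading at all.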